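The source may report more compounds than this note shows. Statements on the series, on what has been measured and on what is new or still open speak of the compounds shown alone.

Measured so far:
- compound 1 `CCOC(=O)c1cc(-c2ccc(OC)cc2)n(-c2ccc(S(N)(=O)=O)cc2)c1C`: 16100 nM
- compound 2 `NS(=O)(=O)c1ccc(-c2cc(C(=O)C3CCC3)nn2-c2ccc(Cl)cc2)cc1`: 17200 nM

In a physicochemical assay for solubility, read by HPLC, in phosphate buffer, measured as kinetic solubility, at pH 7.4 (a lower number here means a less soluble compound, a higher number a more soluble compound), compound 1 gives 16100 nM. In this assay compound 2 gives 17200 nM. Compound 2 is one of only two measured points, and its nearest neighbour, compound 1, lies within the scatter of it, so the two cannot be told apart on this read-out. Within the data shown here, no pair of measured compounds differs in one place, so no single change has yet been tested.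

Compound 3 `NS(=O)(=O)c1ccc(-c2cc(C(=O)NC3CC3)nn2-c2ccc(Cl)cc2)cc1` follows from compound 2 by one change: cyclopropylamino in place of cyclobutyl on a carbonyl carbon. The cyclobutylcarbonyl becomes a cyclopropylcarbamoyl, bringing in one hydrogen-bond donor where none stood before; the two compounds are otherwise the same.

Among the measured compounds shown here, with no measured step of this kind to lean on, the expectation rests on the value of compound 2 alone, 17200 nM, and on the counted change. The step of a 1.7-fold higher number from compound 2 to compound 3 (0.24 log units; within the scatter) is expected to be modest and upward, near the edge of the scatter rather than clearly beyond it. Compound 3 is therefore estimated at 30000 nM, with a range from 12000 nM to 70000 nM.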

Compound 3, solubility: 72600 nM
Compound 3: middle estimate off by 2.4-fold (0.38 log units), on the low side; measured number above the stated range.
By their numbers in this assay, from the lowest: compounds 1 and 2 (each within the scatter of the next); then compound 3.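

In this assay, the carbonyl carbon now has its first measured single change: cyclopropylamino in place of cyclobutyl gives a 4.2-fold higher number from compound 2 to compound 3 (0.63 log units; beyond the scatter), so the read-out does respond to a change at this place. The exchange keeps the heavy-atom count of the group but brings in a nitrogen and a hydrogen-bond donor and replaces the four-membered ring with a three-membered ring, all in one step, so the compounds cannot assign the step to any one of these differences. No measurement bearing on the origin of the step is available.

From the compounds shown here alone, it remains open whether the step follows the amide hydrogen or the ring size: cyclobutylamino or cyclopropyl on the same carbonyl carbon would keep one of the two fixed while the other changes. Also open, going by these compounds, is what an open-chain alkylamino group, a longer chain on the nitrogen or a carboxylic acid would do at this place, and whether a step of this kind carries over to the core of compound 1.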